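The source may hold more compounds than are shown below. What is called first, only, known or untested is meant among the compounds shown, and "the series" means these compounds.

Measured so far in a functional assay on the whole organism for inhibition, with Hamster (Cricetinae) as the target, at a dose of 3 mg/kg by the intravenous route; on this read-out higher numbers stand for a stronger effect at the one dose given and lower numbers for a weaker effect:
compound 1, `COC(=O)C(=O)[C@@H](NC(=O)[C@@H]1CCCN1C(=O)[C@@H](NC(=O)Cn1ccc(=O)n(CC(=O)O)c1=O)C(C)C)C(C)C`, gives 43%;
compound 2, `COC(=O)C(=O)[C@@H](NC(=O)[C@@H]1CCCN1C(=O)[C@@H](NC(=O)CN1CCN(CC(=O)O)C(=O)C1=O)C(C)C)C(C)C`, gives 48%.

Compound 1 stands lowest of these two numbers, but the step of a number 5 percentage points higher from compound 1 to compound 2 (within the scatter) is within the scatter, so the two cannot be told apart. Compound 3, `CC(C)[C@H](NC(=O)Cn1ccc(=O)n(CC(=O)O)c1=O)C(=O)N1CCC[C@H]1C(=O)N[C@H](C(=O)C(F)(F)F)C(C)C`, differs from compound 1 by trifluoromethyl in place of methoxycarbonyl on a carbonyl carbon. Among the compounds with values here, the only measured step concerns a different place in the shared core, so no measured step in this assay bears on this change, and no shift beyond the scatter can be expected in either direction. Compound 3 is therefore estimated at 45%, between 15% and 75%. The expected step is a number 2 percentage points higher from compound 1 to compound 3 (within the scatter).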

Compound 3, a percentage reported as inhibition, in the whole organism at one dose (the size of the read-out at that dose, not a potency): 7.6%
For compound 3 the middle estimate is 37.4 percentage points above the measured one; the whole stated range lies above it.
By their numbers in this assay, from the lowest: compound 3; then compounds 1 and 2 (each within the scatter of the next).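

In this assay, within the data shown here, trifluoromethyl in place of methoxycarbonyl on a carbonyl carbon gives a number 35.4 percentage points lower from compound 1 to compound 3 (beyond the scatter) and is thus the first change here to go beyond the scatter. Among these compounds, the read-out therefore depends on the group at this place, whereas the one earlier step, at another place in the shared core, did not separate its two compounds. Nothing available explains this drop.

Going by these compounds, whether the same change would lower the number on the core of compound 2 remains open. So does how a methyl group or an ethyl ester would fare on this carbonyl carbon.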